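Swapping the N-aryl ring on a triazole cytotoxicity series

The source may hold more compounds than are shown below. What is called first, only, known or untested is meant among the compounds shown, and "the series" means these compounds.

Measured so far:
- compound 1 `Oc1cc(C(F)(F)F)ccc1-c1nc(-c2ccccc2O)n(-c2cccc(C(F)(F)F)c2)n1`: 92.2%
- compound 2 `COc1cccc(-n2nc(-c3ccc(C(F)(F)F)cc3O)nc2-c2ccccc2O)c1`: 96.8%

In a functional assay on PC-12 cells (Rattus norvegicus) for cytotoxicity, read by MTT assay, with stated times of 2 h and 24 h, tested at 5 uM (a lower number here means a weaker effect, a higher number a stronger effect of the compound at the concentration tested), compound 2 gives 96.8%, the higher of the two numbers, with compound 1 nearest at a step of a number 4.6 percentage points higher from compound 1 to compound 2 (within the scatter). Compound 3 `Cc1ccc(-n2nc(-c3ccc(C(F)(F)F)cc3O)nc2-c2ccccc2O)c(C)c1` differs from compound 2 only at the aromatic nitrogen of the shared core: 2,4-dimethylphenyl in place of 3-methoxyphenyl on an aromatic nitrogen. Within the data shown here, the one measured step that touches the same ring, the change on an aromatic carbon of that ring from compound 1 to compound 2, was a number 4.6 percentage points higher from compound 1 to compound 2 (within the scatter) and stayed within the scatter. On that basis a change of the whole ring is expected to move the number little, so the step of a number 2.8 percentage points lower from compound 2 to compound 3 (within the scatter) is estimated to stay within the scatter. Compound 3 is therefore expected to give about 94%, within a range of 84% to 100%.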

Compound 3, a percentage reported as activity, at one concentration (the size of the read-out at that concentration, not a potency): 93.3%
The estimate for compound 3 lay 0.7 percentage points above the measured number, within the range that was stated.
By their numbers in this assay, from the lowest: compounds 1, 3 and 2 (each within the scatter of the next).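

In this assay, the aromatic nitrogen of the shared core took 2,4-dimethylphenyl in place of 3-methoxyphenyl with a number 3.5 percentage points lower from compound 2 to compound 3 (within the scatter), and in place of 3-(trifluoromethyl)phenyl with a number 1.1 percentage points higher from compound 1 to compound 3 (within the scatter). Among these compounds, the earlier pair had changed only one group on an aromatic carbon of this ring, whereas these steps exchange the whole aryl group, including for one made of carbon alone, and compounds 1, 2 and 3 still cannot be told apart in this read-out. No supporting data accompany these numbers to account for them.

Every group shown at this nitrogen is a substituted phenyl, so the effect of an amine or a carboxylic acid on the ring, or of a longer alkyl chain in place of it, remains open. On these data alone, with a read-out at one concentration, how the size of the effect of the three compounds compares at other concentrations also remains open.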